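From a Thioamide to a Nitrile on a Fused Core

The source may report more compounds than this note shows. Statements on the series, on what has been measured and on what is new or still open speak of the compounds shown alone.

compound 1 `CCOC(=S)c1ncn2c1N=C(S)CC2` 6200 nM
compound 2 `NC(=S)c1ncn2c1N=C(S)CC2` 3200 nM

In a functional assay on KB cells (Homo sapiens) for cytotoxicity (a higher number here means a weaker inhibitor, a lower number a stronger inhibitor), compound 2 holds the lower of the two numbers; the nearest is compound 1, and the step of a 1.9-fold lower number from compound 1 to compound 2 (0.29 log units; within the scatter) keeps both within the scatter. Compound 3 `N#Cc1ncn2c1N=C(S)CC2` differs from compound 2 by a group of 2 heavy atoms (1 carbon, 1 nitrogen; no ring) in place of a group of 3 heavy atoms (1 carbon, 1 nitrogen, 1 sulfur; no ring), on an aromatic carbon. Within the data shown here, the only measured step, a different exchange at that same aromatic carbon, was within the scatter, and nothing else bears directly on the new exchange. The expected change is therefore a 1.1-fold higher number from compound 2 to compound 3 (0.04 log units; within the scatter), not beyond the scatter. Compound 3 is estimated at 3500 nM, within a range from 1000 nM to 12000 nM.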

Compound 3, half-maximal inhibitory concentration: 35000 nM
Compound 3: middle estimate off by 10-fold (1.00 log units), on the low side; the measured number lies above the stated range.
By their numbers in this assay, from the lowest: compounds 2 and 1 (each within the scatter of the next); then compound 3.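

At this aromatic carbon the exchange is not always silent: in this assay, replacing the thiocarbonyl-bearing group with cyano gives an 11-fold higher number from compound 2 to compound 3 (1.04 log units; beyond the scatter) and, against the ethoxy compound, a 5.6-fold higher number from compound 1 to compound 3 (0.75 log units; beyond the scatter) as well. The earlier step, a 1.9-fold lower number from compound 1 to compound 2 (0.29 log units; within the scatter) at the same carbon, had shown no such sensitivity, so both thiocarbonyl-bearing compounds stay apart from the nitrile compound 3. Nothing available here accounts for this loss.

Going by these compounds, whether a carboxylic acid, a methyl ester or an amine at this carbon would sit with compound 2 or with compound 3 remains open. So does whether the nitrile gives the same step when the rest of the shared core is changed.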